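Sulfonamide series: aryl swap at the assay limit

A few compounds are considered here, and "the series" means these few. Any claim that something is new, unique, unknown or untested is made for them only; others in the source may bear on it.

Measured in a functional assay on cells (leukaemia cell line, Homo sapiens) for inhibition, read by sulforhodamine B assay, with a stated time of 48 h; a lower number here means that less compound is tolerated, a higher number that more compound is tolerated:
Compound 1 `O=S(=O)(Nc1ccc(Cl)c(Cl)c1)c1ccc(-c2cnc(C3CC3)o2)cc1` gives > 100000 nM as a limit
Compound 2 `Cc1cc(NS(=O)(=O)c2ccc(-c3cnc(C4CC4)o3)cc2)ccc1Cl` gives > 100000 nM as a limit

Compound 2 has no number, only the limit > 100000 nM and nothing more. Going by the values given here, the whole series so far sits at one bound: the limit of > 100000 nM in this assay, at which 2 of the 2 values shown sit, is all the evidence there is. Among the compounds with values here, the only measured step is a step that the two limits leave unreadable from compound 1 to compound 2 and gives no size to carry forward.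

Compound 3 `O=S(=O)(Nc1cc(F)cc(Cl)c1)c1ccc(-c2cnc(C3CC3)o2)cc1` brings this change: 3-chloro-5-fluorophenyl in place of 4-chloro-3-methylphenyl on a sulfonamide nitrogen with 3-chloro-5-fluorophenyl in place of 4-chloro-3-methylphenyl on a sulfonamide nitrogen. No step beyond the scatter and no direction is expected in this assay on this basis. The expected step is a number no higher from compound 2 to compound 3 (the limit leaves the size open) as an estimate only. For compound 3 the estimated value is 100000 nM with an expected range from 50000 nM to 150000 nM and another limit is the likeliest report.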

Compound 3, concentration lethal to 50% of the cells: > 100000 nM
Compound 3 gave a limit, no number (the forecaster's own chance of this, stated with the estimate: 85%); the middle value lies on the limit itself.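

Compound 3 gives only a limit, > 100000 nM, and the steps linking compound 1, compound 2 and compound 3 cannot be read. Whether these three compounds differ at all in this assay stays open: the limit of > 100000 nM in this assay, at which 3 of the 3 values shown sit.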